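From 2-methoxyphenyl to 3-nitrophenyl: an expected step

The source may hold more compounds than are shown below. What is called first, only, known or untested is meant among the compounds shown, and "the series" means these compounds.

Of the compounds shown here, three sharing one core have been measured in a functional assay on MCF7 cells (Homo sapiens) for cytotoxicity, read by MTT assay, with a stated time of 48 h; on this read-out higher numbers stand for weaker inhibition and lower numbers for stronger inhibition. Compound 1 (`CCN(CC)C(=S)SC(CC(=O)c1ccccc1)c1ccccc1`) gives 17000 nM, compound 2 (`CCN(CC)C(=S)SC(CC(=O)c1ccccc1)c1ccc(F)cc1`) gives 700 nM, and compound 3 (`CCN(CC)C(=S)SC(CC(=O)c1ccccc1)c1ccccc1OC`) gives 16000 nM. Compound 3 thus sits with compound 1 at the high end of these numbers, well away from compound 2.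

Compound 4 (`CCN(CC)C(=S)SC(CC(=O)c1ccccc1)c1cccc([N+](=O)[O-])c1`) has 3-nitrophenyl in place of 2-methoxyphenyl on a saturated chain carbon bound to a saturated chain carbon and a sulfur.

Within the data shown here, three measured steps concern this same aromatic group. Methoxy in place of hydrogen gave a 1.1-fold lower number from compound 1 to compound 3 (0.03 log units; within the scatter), while fluoro in place of hydrogen gave a 24-fold lower number from compound 1 to compound 2 (1.39 log units; beyond the scatter). Replacing 4-fluorophenyl with 2-methoxyphenyl gave a 23-fold higher number from compound 2 to compound 3 (1.36 log units; beyond the scatter). Among the measured compounds shown here, no compound carrying a nitro group has been measured, so these steps show only that a change on this group can leave the number unmoved or shift it strongly.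

With both outcomes on record, a moderate move toward a lower number is expected in this assay, estimated as a 3.2-fold lower number from compound 3 to compound 4 (0.51 log units; beyond the scatter). Compound 4 is estimated at 5000 nM, with an expected range of 900 nM to 20000 nM.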

Compound 4, half-maximal inhibitory concentration: 9000 nM
For compound 4 the middle estimate is 1.8-fold (0.26 log units) below the measured one; measured number inside the range.
By their numbers in this assay, from the lowest: compound 2; then compounds 4, 3 and 1 (each within the scatter of the next).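

A nitro group added to the plain phenyl gives a 1.9-fold lower number from compound 1 to compound 4 (0.28 log units; within the scatter) and 3-nitrophenyl in place of 2-methoxyphenyl gives a 1.8-fold lower number from compound 3 to compound 4 (0.25 log units; within the scatter) in this assay; a second group on this aromatic ring, of a different kind from methoxy, therefore also stays within the scatter of the plain phenyl of compound 1. Replacing 4-fluorophenyl with 3-nitrophenyl gives a 13-fold higher number from compound 2 to compound 4 (1.11 log units; beyond the scatter), so compound 2 now stands apart from three compounds that lie within the scatter of one another, and among the four compounds the large step belongs to 4-fluorophenyl alone. Nothing available bears on why these groups behave as they do.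

Group and ring place change together across 4-fluorophenyl, 3-nitrophenyl and 2-methoxyphenyl, so these compounds cannot separate what belongs to fluoro itself from what belongs to where it sits on the ring. On these data alone, it also remains open whether chloro, an amine or a carboxylic acid on this aromatic ring would join compound 2 or stay with the other three compounds.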